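The source may hold more compounds than are shown below. What is called first, only, known or untested is meant among the compounds shown, and "the series" means these compounds.

Among the measured compounds shown here, in a functional assay on ACHN cells (Homo sapiens) (a lower number here means a stronger inhibitor of growth, a higher number a weaker inhibitor of growth), compound 2 `O=S(=O)(/C=C/c1ccc(F)cc1Cl)Cc1ccc(Nc2ncnc3ccccc23)cc1` gives 73000 nM and stands highest of the two numbers so far, while compound 1 `O=S(=O)(/C=C/c1ccc(Cl)c(Cl)c1)Cc1ccc(Nc2ncnc3ccccc23)cc1` gives 28000 nM in the same measure. Compound 3 `O=S(=O)(/C=C/c1ccc(O)cc1)Cc1ccc(Nc2ncnc3ccccc23)cc1` departs from compound 2 by one change: 4-hydroxyphenyl in place of 2-chloro-4-fluorophenyl on a double-bonded chain carbon bound to a double-bonded chain carbon and nothing else. For the measured compounds named here, the one measured step at that place is a 2.6-fold higher number from compound 1 to compound 2 (0.42 log units; beyond the scatter) and so a step no larger is expected in this assay toward a lower number, though the direction has little support. The estimate for compound 3 is 40000 nM with an expected range from 13000 nM to 100000 nM in this measure. That estimate means a 1.8-fold lower number from compound 2 to compound 3 (0.26 log units; within the scatter) as the expected step.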

Compound 3, concentration for 50% growth inhibition: 20 nM
Estimate against measurement, compound 3: 2000-fold (3.30 log units) above; measured number below the stated range.
By their numbers in this assay, from the lowest: compound 3; then compound 1; then compound 2.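

In this assay, replacing either halogenated ring with 4-hydroxyphenyl gives a 3700-fold lower number from compound 2 to compound 3 (3.56 log units; beyond the scatter) and a 1400-fold lower number from compound 1 to compound 3 (3.15 log units; beyond the scatter). This position therefore controls growth inhibition far more strongly than the difference between the two halogenated groups had suggested. No available evidence bears on why the change has so large an effect.

The compounds shown leave open whether the gain follows the hydroxy group itself or the loss of the halogens. They also leave open whether a methoxy group or an amine could sustain it.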